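Swapping Cyano for Trifluoromethyl and Cell Toxicity

A few compounds are considered here, and "the series" means these few. Any claim that something is new, unique, unknown or untested is made for them only; others in the source may bear on it.

Compound 1 `CN1CCCN(c2ccc(C#N)c(CN3CCN(C(c4ccc(F)cc4)c4ccc(F)cc4)CC3)c2)CC1` and compound 3 `CN1CCCN(c2ccc(C(F)(F)F)c(CN3CCN(C(c4ccc(F)cc4)c4ccc(F)cc4)CC3)c2)CC1` were both tested in a toxicity assay on Huh-7.5 cells (Homo sapiens) for cytotoxicity, read by MTT assay, with a stated time of 96 h; on this read-out lower numbers stand for higher toxicity in this test and higher numbers for lower toxicity in this test. Compound 1 gives 6240 nM, and compound 3 gives 1450 nM. The change between them, (trifluoromethyl in place of cyano on an aromatic carbon), made the step of a 4.3-fold lower number from compound 1 to compound 3 (0.63 log units; beyond the scatter). Compound 2 `CN(C)CCN(C)c1ccc(C#N)c(CN2CCN(C(c3ccccc3)c3ccc(Cl)cc3)CC2)c1` has a core that differs from that of compound 1 in a way not broken down here; in this assay compound 2 gives 5660 nM. Compound 4 `CN(C)CCN(C)c1ccc(C(F)(F)F)c(CN2CCN(C(c3ccccc3)c3ccc(Cl)cc3)CC2)c1` carries the same kind of change relative to compound 2, (trifluoromethyl in place of cyano on an aromatic carbon), though here the place is para to a (2-(dimethylamino)ethyl)(methyl)amino group rather than para to a 4-methyl-1,4-diazepan-1-yl group. The step of a 3.8-fold lower number from compound 2 to compound 4 (0.58 log units; beyond the scatter) is expected, because the same kind of change gave a 4.3-fold lower number from compound 1 to compound 3 (0.63 log units; beyond the scatter). Compound 4 is thus estimated at 1500 nM, with a likely range from 700 nM to 3500 nM.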

Compound 4, half-maximal cytotoxic concentration: 6960 nM
Beside the measured number, compound 4's estimate is 4.6-fold (0.67 log units) below it; measured number outside the range, above it.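

The step from cyano to trifluoromethyl did not carry over from one core to the other in this assay: the same change on two cores in this assay, a 4.3-fold lower number (0.63 log units; beyond the scatter) from compound 1 to compound 3 and a 1.2-fold higher number (0.09 log units; within the scatter) from compound 2 to compound 4, 5.3-fold (0.72 log units) apart, beyond the scatter of two such steps. On the core of compound 2, the swap gives a 1.2-fold higher number from compound 2 to compound 4 (0.09 log units; within the scatter) and so makes no readable difference, unlike on the core of compound 1. Within the data shown here, this shows that the result on one core was a poor guide to the other, but with only two pairs it does not show which difference between the cores is responsible.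

Going by these compounds, it remains open whether the (2-(dimethylamino)ethyl)(methyl)amino group alone separates the two outcomes, since the cores differ in more than that group. On these data alone, it is also open how a methyl group or a carboxylic acid in the same place would read on either core.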